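The compounds below may be only part of what the source reports. "The series", "measured", "known", "first", "only" and "open" are said of these compounds alone.

Measured so far:
compound 1 `O=C(Nc1cccc(-n2cc(-c3ccncc3)c(-c3cc(O)cc(Cl)c3)n2)c1)Nc1ccc(Cl)c(C(F)(F)F)c1` — 108%
compound 2 `O=C(Nc1cccc(-n2cc(-c3ccncc3)c(-c3cc(O)cc(Cl)c3)n2)c1)Nc1ccc(Cl)c(Cl)c1` — 108%

In a functional assay on SK-OV-3 cells (Homo sapiens) for inhibition, read by sulforhodamine B assay, with a stated time of 48 h, tested at 0.01 uM (a lower number here means a stronger effect, a higher number a weaker effect of the compound at the concentration tested), compound 1 gives 108%; compound 2 gives 108%. Within the data shown here, compound 1 therefore stands level with compound 2, and the one step between them, chloro in place of trifluoromethyl on an aromatic carbon, reads no change at the digits printed from compound 1 to compound 2 (within the scatter). Neither compound shows any effect at this concentration.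

Compound 3 `COc1cc(Cl)cc(-c2nn(-c3cccc(NC(=O)Nc4ccc(Cl)c(C(F)(F)F)c4)c3)cc2-c2ccncc2)c1` has not been measured. It differs from compound 1 by methyl in place of hydrogen on an oxygen on an aromatic ring. Among the measured compounds shown here, the single measured step, no change at the digits printed from compound 1 to compound 2 (within the scatter), concerns a different part of the molecule, so no step bears on a change at this oxygen. With nothing to point in either direction, the expectation is a step of a number 3 percentage points lower from compound 1 to compound 3 (within the scatter), that is, none beyond the scatter. Compound 3 is accordingly estimated at 105%, in the range 90% to 120%.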

Compound 3, a percentage reported as activity, at one concentration (the size of the read-out at that concentration, not a potency): 104%
For compound 3 the middle estimate is 1 percentage points above the measured one, within the range that was stated.
By their numbers in this assay, from the lowest: compounds 3, 1 and 2 (each within the scatter of the next).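

In this assay, among these compounds, the change from hydroxy to methoxy reads a number 4 percentage points lower from compound 1 to compound 3 (within the scatter), the first step at this oxygen, since the earlier pair differed elsewhere in the molecule. Compound 3 joins compounds 1 and 2 in showing no effect at this concentration, so the hydroxy hydrogen can be replaced by methyl without any visible change here, but with no effect to lose, this says nothing about whether that hydrogen matters for activity. No measurement at hand bears on why the read-out stays flat.

The compounds shown leave open whether hydroxy and methoxy would separate at concentrations where an effect appears. They also leave open how a longer chain such as ethoxy, or an amine in place of the hydroxy, would read at this position.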